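Trifluoromethoxy replaces iodo on the aryl urea

The source may report more compounds than this note shows. Statements on the series, on what has been measured and on what is new or still open speak of the compounds shown alone.

Measured compounds:
compound 1 `O=C(Nc1cccc(F)c1)N[C@H]1CC[C@H](Oc2ccc(F)cc2)CC1` with 8300 nM
compound 2 `O=C(Nc1ccccc1I)N[C@H]1CC[C@H](Oc2ccc(F)cc2)CC1` with > 20000 nM
compound 3 `O=C(Nc1ccc(F)cc1)N[C@H]1CC[C@H](Oc2ccc(F)cc2)CC1` with 20000 nM

All three share the same core and differ only in the aryl group on the urea nitrogen. In a functional assay on CRL2813 cells (Homo sapiens) for cytotoxicity, read by sulforhodamine B assay, with a stated time of 5 days (on this read-out lower numbers stand for stronger inhibition and higher numbers for weaker inhibition), compound 1 gives 8300 nM, the lowest number of the three. For compound 2 the assay reports only a limit, > 20000 nM, not a number. Compound 3 gives 20000 nM. The step of an at least 2.4-fold higher number from compound 1 to compound 2 (0.38 log units; beyond the scatter) and the step of a 2.4-fold higher number from compound 1 to compound 3 (0.38 log units; beyond the scatter) both move away from compound 1; the step of a number no higher from compound 2 to compound 3 (the limit leaves the size open) cannot be sized because of the limit of > 20000 nM in this assay, at which 1 of the 3 values shown sits.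

Compound 4 `O=C(Nc1ccccc1OC(F)(F)F)N[C@H]1CC[C@H](Oc2ccc(F)cc2)CC1` is not yet measured. It differs from compound 2 by trifluoromethoxy in place of iodo on an aromatic carbon. For the measured compounds named here, no measured step matches this change, since compound 2 stands at the limit of > 20000 nM in this assay, at which 1 of the 3 values shown sits, and the steps from compound 1 show only that moving the substituent or enlarging it raises the number. Compound 4 is therefore expected to stay near the weak end, with the step of a number no higher from compound 2 to compound 4 (the limit leaves the size open) expected to lie within the scatter. The estimate for compound 4 is 20000 nM, ranging from 8000 nM to 50000 nM.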

Compound 4, half-maximal inhibitory concentration: > 20000 nM
Compound 4: no number, only a limit; the forecaster's own chance of this, stated with the estimate: 55%; the middle value sits exactly at the limit.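

In this assay, compound 4 gives only a limit, > 20000 nM, and not a number. Compound 2 also carries only a limit, so no step between compound 2 and compound 4 can be read: the limit of > 20000 nM in this assay, at which 2 of the 4 values shown sit.

On these data alone, how trifluoromethoxy and iodo compare on the aryl urea stays open, as does how far either compound lies past the limit.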